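This account rests on a few compounds, and the source may have more. Where it says the series, first, only, none or still open, it means among the compounds named here.

Working notes on the series, all read in a functional assay on HL-60 cells (Homo sapiens) for cytotoxicity, read by MTT assay, with a stated time of 72 h; a higher number here means a weaker inhibitor, a lower number a stronger inhibitor. Compound 1 (`C=C1CC[C@]23C(C(=O)OC)=CCC[C@H]2[C@]12C[C@H](c1ccoc1)O[C@H]2O[C@H]3O`) gives >= 10000 nM as a limit of the assay and not a number. Compound 2 (`C=C1C[C@H](OC(C)=O)[C@]23C(C(=O)OC)=CCC[C@H]2[C@]12C[C@H](c1ccoc1)O[C@H]2O[C@@H]3O`) gives >= 10000 nM as a limit of the assay and not a number. That leaves compound 2 without a number to count from, and the whole record so far is the limit of >= 10000 nM in this assay, at which 2 of the 2 values shown sit, and nothing else.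

Compound 3 (`C=C1C[C@H](OC(C)=O)[C@]23C(C(=O)OC)=CCC[C@H]2[C@]12C[C@H](c1ccoc1)O[C@H]2O[C@H]3O`) is the next to be read against compound 2. The structural change is the two compounds have the same atoms and bonds and differ only in configuration as drawn: 1 of 7 stereo elements differ; a stereocentre at a saturated ring carbon is drawn S in compound 2 and R in compound 3 and nothing leaves or enters. Among the compounds with values here, no measured step shows what such a change in configuration does, so any expectation rests on the standing of compound 2 alone. With compound 2 at >= 10000 nM as a limit, no step beyond the usual scatter is expected, in either direction. The expected size of the change is a number no higher from compound 2 to compound 3 (the limit leaves the size open) in this estimate. Compound 3 is expected at 10000 nM with an estimated range from 4000 nM to 20000 nM and may well prove to be only a limit.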

Compound 3, half-maximal inhibitory concentration: >= 10000 nM
Compound 3 was reported as a limit; the forecaster's own chance of this, stated with the estimate: 80%; the middle value lies on the limit itself.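

Compound 3 gives >= 10000 nM, a limit of the assay and not a number. No step can be read from compound 2 to compound 3 or from compound 1 to compound 3. The compounds shown leave open whether the acetoxy group or the configuration at the saturated ring carbon affects the read-out at all, because the record holds only one reading: the limit of >= 10000 nM in this assay, at which 3 of the 3 values shown sit.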